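The compounds below may be only part of what the source reports. "The series", "measured", "known", "first", "only" and "open" are said of these compounds alone.

Measured compounds in an assay for displacement of a labelled ligand from DNA repair protein REV1 (Homo sapiens), read by fluorescence polarization, with a stated time of 1 h; on this read-out lower numbers stand for stronger inhibition and higher numbers for weaker inhibition:
- compound 1 `CC(=O)N1CCC(C(=O)Nc2sc3c(c2C(=O)NC2CC2)CCC(C)C3)CC1` gives 4600 nM
- compound 2 `CC(=O)N1CCC(C(=O)Nc2sc3c(c2C(N)=O)CCC(C)C3)CC1` gives 15700 nM

Of these two numbers, compound 1 has the lower one, so it is the stronger binder in this assay, with compound 2 separated by a 3.4-fold higher number from compound 1 to compound 2 (0.53 log units; beyond the scatter). That step swaps the cyclopropyl on the amide nitrogen for hydrogen.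

Compound 3 `CC(=O)N1CCC(C(=O)Nc2sc3c(c2C(=O)NC2CC2)CCCC3)CC1` has not been measured. It differs from compound 1 at a different place: hydrogen in place of methyl on a saturated ring carbon. Within the data shown here, the only step recorded so far, from compound 1 to compound 2, concerns a group elsewhere on the shared core, so no measured step speaks directly to the loss of this ring methyl. Without a step at this position to rest on, the change from compound 1 to compound 3 is expected to be small, a 1.4-fold higher number from compound 1 to compound 3 (0.15 log units; within the scatter), likely inside the scatter or only slightly weaker. Compound 3 is therefore estimated to give 6500 nM in this assay, within a range of 2500 nM to 16000 nM.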

Compound 3, inhibition constant: 31500 nM
Beside the measured number, compound 3's estimate is 4.8-fold (0.69 log units) below it; the whole stated range lies below it.
By their numbers in this assay, from the lowest: compound 1; then compounds 2 and 3 (each within the scatter of the next).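

In this assay the saturated ring carbon is not a neutral spot, as the loss of one methyl gives a 6.8-fold higher number from compound 1 to compound 3 (0.84 log units; beyond the scatter) and so moves the number beyond the scatter. This single carbon, a small change with no hydrogen-bond donors or acceptors leaving, therefore counts in this series, just as the group on the amide nitrogen does in a 3.4-fold higher number from compound 1 to compound 2 (0.53 log units; beyond the scatter) and with the same direction of change. Nothing measured here explains the loss.

At this ring carbon the compounds shown hold only methyl and hydrogen, so it remains open whether a longer chain such as ethyl, or a hydroxyl group, would give a lower or a higher number than methyl. Also open, as far as these compounds go, is whether removing the methyl costs the same when hydrogen replaces the cyclopropyl on the amide nitrogen.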